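Swapping Cyclohexyl for Phenoxy on the Tether

The compounds below may be only part of what the source reports. "The series", "measured", "known", "first", "only" and "open" are said of these compounds alone.

Compound 1 `CN1Cc2ccc(OCCCc3ccccc3)cc2[C@@H](O)C1` and compound 2 `CN1Cc2ccc(OCCC3CCCCC3)cc2[C@@H](O)C1` share one core and differ only in the ring at the end of the chain. In an ADME assay on Vero cells (Chlorocebus sabaeus) for cytotoxicity, read by sulforhodamine B assay, with a stated time of 72 h (a lower number here means a stronger inhibitor, a higher number a weaker inhibitor), compound 1 reaches only the limit of the assay, > 50000 nM. In this assay compound 2 likewise reaches only the limit, > 50000 nM. The step that the two limits leave unreadable from compound 1 to compound 2 therefore cannot be sized. Where compound 2 stands is captured by the limit of > 50000 nM in this assay, at which 2 of the 2 values shown sit, and nothing more. Compound 3 `CN1Cc2ccc(OCCOc3ccccc3)cc2[C@@H](O)C1` is not yet measured; it differs from compound 2 by phenoxy in place of cyclohexyl on a saturated chain carbon, two bonds along the chain from an oxygen on an aromatic ring. For the measured compounds named here, no measured step bears on this change: the single recorded step was unreadable, so no direction and no size beyond scatter can be foreseen in this assay. Compound 3 is expected to sit at 60000 nM, within 25000 nM to 150000 nM. The step that the limit leaves unreadable from compound 2 to compound 3 is thus only an estimate. Compound 3 is expected most likely to give only a limit of the assay as well.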

Compound 3, half-maximal inhibitory concentration: > 100000 nM
Compound 3: a limit, no number; the forecaster's own chance of this, stated with the estimate: 85%; at least 1.6-fold (0.22 log units) between middle value and limit.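

In this assay, for the compounds shown here, compound 1, compound 2 and compound 3 each give only a limit of the assay and not a number, so no step among them can be read. The compounds shown leave open whether changing the end group alters cytotoxicity at all.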